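Series notes: replacing the pyrrolidinyl ether by hydroxypropoxy

A few compounds are considered here, and "the series" means these few. Any claim that something is new, unique, unknown or untested is made for them only; others in the source may bear on it.

Compound 3 `COc1ccc2c(c1)C[C@@H](C(=O)Nc1ccc(-c3cn[nH]c3)cc1O[C@H]1CCN(C)C1)CO2` stands at the top of the numbers shown in an assay on A7R5 cells for inhibition of Rho-associated protein kinase 2 (Rattus norvegicus), with a stated time of 1 h; a lower number here means a stronger inhibitor, a higher number a weaker inhibitor: compound 3 gives 900 nM. Its nearest neighbour is compound 1 `COc1ccc2c(c1)C[C@@H](C(=O)Nc1ccc(-c3cn[nH]c3)cc1O[C@@H]1CCN(C)C1)CO2`, which in this assay gives 32 nM; the step of a 28-fold higher number from compound 1 to compound 3 (1.45 log units; beyond the scatter) is large and arises from the fact that compounds 1 and 3 differ only in the configuration as drawn. Compound 2 `COc1ccc2c(c1)C[C@H](C(=O)Nc1ccc(-c3cn[nH]c3)cc1O[C@@H]1CCN(C)C1)CO2` sits at a limit of this assay, < 4 nM. The step of an at least 8.0-fold lower number from compound 1 to compound 2 (0.90 log units; beyond the scatter) rests on (the fact that compounds 1 and 2 differ only in the configuration as drawn), and the step of an at least 220-fold higher number from compound 2 to compound 3 (2.35 log units; beyond the scatter) on (the fact that compounds 2 and 3 differ only in the configuration as drawn); each configurational change moves the number well beyond the scatter.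

Compound 4 `COc1ccc2c(c1)C[C@@H](C(=O)Nc1ccc(-c3cn[nH]c3)cc1OCCCO)CO2` has not yet been measured. It differs from compound 3 by 3-hydroxypropyl in place of 1-methylpyrrolidin-3-yl on an oxygen on an aromatic ring. Among the measured compounds shown here, none of the measured steps involves this exchange; all three concern configuration only. The group that leaves carries one defined stereocentre, and the step of a 28-fold higher number from compound 1 to compound 3 (1.45 log units; beyond the scatter) shows how strongly that configuration moves the number, while compound 4 carries no such stereocentre, so its number is expected to fall between those of compound 1 and compound 3 rather than at either end. Compound 4 is therefore expected to give 100 nM, within 20 nM to 600 nM. The expected step is a 9.0-fold lower number from compound 3 to compound 4 (0.95 log units; beyond the scatter).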

Compound 4, half-maximal inhibitory concentration: 519 nM
Beside the measured number, compound 4's estimate is 5.2-fold (0.72 log units) below it, and the stated range covers the measured number.
By their numbers in this assay, from the lowest: compound 1; then compounds 4 and 3 (each within the scatter of the next). At a limit, below all of these: compound 2.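

In this assay the exchange of 1-methylpyrrolidin-3-yl for 3-hydroxypropyl on an oxygen on an aromatic ring gives a 1.7-fold lower number from compound 3 to compound 4 (0.24 log units; within the scatter) and leaves the two compounds unseparated, so at this position an open chain with no defined stereocentre reads the same as the ring group in the configuration of compound 3. Among the compounds shown here, the same exchange read from the other configuration gives a 16-fold higher number from compound 1 to compound 4 (1.21 log units; beyond the scatter) and is large, so the size of this change depends on which configuration of the leaving group is taken as the reference, whereas the earlier compounds showed only that configuration moves the number. The information at hand bears on configuration alone and offers nothing on why this exchange reads as it does.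

For the compounds shown here, it remains open whether 3-hydroxypropyl would read differently on the core configuration of compound 2, the one compound that sits at a limit of the assay. Also open, going by these compounds, is how a 3-aminopropyl chain, a carboxylic acid or a longer chain ending in a hydroxyl would read on the same oxygen, and so whether the hydroxyl or the chain accounts for the number of compound 4.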